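Working notes: from compound 2 to compound 3

The source may hold more compounds than are shown below. What is called first, only, known or untested is meant among the compounds shown, and "the series" means these compounds.

Measured so far in a functional assay, read by WST assay (a lower number here means a stronger inhibitor, a higher number a weaker inhibitor), with these compounds
- Compound 1 `CC(=O)Oc1ccc(/C=C/C(=O)O[C@@H]2C=C[C@@]3(C[C@H]2O)OC(C)(C)OC3=O)cc1OC(C)=O` gives 2.9 ug/mL as its half-maximal inhibitory concentration
- Compound 2 `CC1(C)OC(=O)[C@@]2(C=C[C@@H](O)[C@H](OC(=O)/C=C/c3ccc(O)c(O)c3)C2)O1` gives 1.5 ug/mL as its half-maximal inhibitory concentration

Compound 2 at 1.5 ug/mL and compound 1 at 2.9 ug/mL lie within the scatter of each other, so the two numbers do not separate these compounds. Compound 3 `CC1(C)OC(=O)[C@@]2(C=C[C@@H](OC(=O)/C=C/c3ccc(O)c(O)c3)[C@H](OC(=O)/C=C/c3ccc(O)c(O)c3)C2)O1` has not been measured yet. It follows from compound 2 by one change ((2-(3,4-dihydroxyphenyl)ethenyl)carbonyl in place of hydrogen on an oxygen on a saturated carbon), with (2-(3,4-dihydroxyphenyl)ethenyl)carbonyl in place of hydrogen on an oxygen on a saturated carbon. For the measured compounds named here, no pair of measured compounds differs in one place, so the data hold no direct precedent for this change. Going by the values given here, the only anchor is compound 2 at 1.5 ug/mL in this assay, and no shift beyond the scatter is expected. The expected size of the change is a 1.3-fold lower number from compound 2 to compound 3 (0.10 log units; within the scatter) in this estimate. For compound 3 the estimated value is 1.2 ug/mL with an expected range from 0.4 ug/mL to 3.5 ug/mL as the working figure, kept wide for want of a precedent.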

Compound 3, half-maximal inhibitory concentration: 2 ug/mL
Estimate against measurement, compound 3: 1.7-fold (0.22 log units) below; low and high end bracket the measured number.
By their numbers in this assay, from the lowest: compounds 2, 3 and 1 (each within the scatter of the next).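

In this assay, for the compounds shown here, this is the first direct reading at the oxygen on a saturated carbon: with (2-(3,4-dihydroxyphenyl)ethenyl)carbonyl in place of hydrogen, the series shows a 1.3-fold higher number from compound 2 to compound 3 (0.12 log units; within the scatter) for this change. Within this single pair, then, the free hydroxyl hydrogen is not required to keep the number within the scatter, and adding this group at this position brings no gain that can be read either. Nothing measured on these compounds gives a reason for this flat result.

From the compounds shown here alone, whether a smaller acetyl, a longer saturated chain, or a chain ending in an amine or a carboxylic acid would also stay within the scatter on this oxygen remains open. Going by these compounds, it is also open whether the same change would read alike on compound 1, whose aromatic ring carries acetyl groups, so one flat step cannot yet be taken as a rule for this position across the series.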